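Chloro for fluoro on the aryl piperazine of compound 1

A few compounds are considered here, and "the series" means these few. Any claim that something is new, unique, unknown or untested is made for them only; others in the source may bear on it.

Measured so far:
compound 1, `Fc1cccc(N2CCN(CCCOc3ccc4c(c3)CCC4)CC2)c1`: 19%
compound 2, `Fc1cccc(N2CCN(CCCCOc3ccc4c(c3)CCC4)CC2)c1`: 15%
compound 3, `Clc1cccc(N2CCN(CCCCOc3ccc4c(c3)CCC4)CC2)c1`: 37%

The three compounds share a core and were tested in a functional assay on the whole organism for inhibition, with Mus musculus as the target, at a dose of 25 mg/kg by the oral route; on this read-out higher numbers stand for more inhibition at the one dose given (going by the name of the read-out) and lower numbers for less inhibition. Compound 1 gives 19%, the second highest of the three numbers. Its nearest neighbour is compound 2, which gives 15%, a gap that lies within the scatter. Going by the values given here, compound 3 gives 37%, the one number beyond the scatter from compound 1.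

Among the compounds with values here, the only step measured between two compounds differing in one place is a number 22 percentage points higher from compound 2 to compound 3 (beyond the scatter).

Compound 4, `Clc1ccc(N2CCN(CCCOc3ccc4c(c3)CCC4)CC2)cc1`, has not yet been measured. It differs from compound 1 in one place: 4-chlorophenyl in place of 3-fluorophenyl on an amine nitrogen in a ring. The change exchanges fluoro for chloro on the phenyl ring, though the group also sits at a different position on that ring, so the measured step bears on it only in part. Because of a number 22 percentage points higher from compound 2 to compound 3 (beyond the scatter) a modest rise is expected, and compound 4 is therefore estimated at 32%, with a range from 12% to 52%. The expected step from compound 1 is a number 13 percentage points higher from compound 1 to compound 4 (beyond the scatter).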

Compound 4, a percentage reported as inhibition, in the whole organism at one dose (the size of the read-out at that dose, not a potency): 43%
Compound 4: middle estimate off by 11 percentage points, on the low side; low and high end bracket the measured number.
By their numbers in this assay, from the lowest: compounds 2 and 1 (each within the scatter of the next); then compounds 3 and 4 (each within the scatter of the next).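

In this assay, the exchange of 3-fluorophenyl for 4-chlorophenyl on an amine nitrogen in a ring gives a number 24 percentage points higher from compound 1 to compound 4 (beyond the scatter), so this position responds to the change on the chain of compound 1 as well, and not only on the different chain of compound 2 and compound 3. Together with a number 22 percentage points higher from compound 2 to compound 3 (beyond the scatter), this makes two steps that bring chloro in place of fluoro, both upward and both beyond the scatter, with no compound shown going against them, although the new step also moves the halogen to another place on the phenyl ring and so cannot be credited to chloro alone. Nothing measured on these compounds accounts for either rise, so the reason for it stays unknown.

The compounds shown leave open how much of the step from compound 1 belongs to the halogen and how much to its place on the ring, a question that fluoro at the place chloro holds in 4-chlorophenyl would help to settle. They also leave open whether a methoxy group or a trifluoromethyl group at that same place would raise the number as chloro does.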